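Swapping Fluoro for Methoxy on a Shared Core

This account rests on a few compounds, and the source may have more. Where it says the series, first, only, none or still open, it means among the compounds named here.

Three compounds built on one shared core were tested in a functional assay on HCT-116 cells (Homo sapiens) for cytotoxicity, read by MTT assay, with a stated time of 48 h, in the presence of a further agent that is not named here; on this read-out lower numbers stand for an effect already at smaller amounts and higher numbers for an effect only at larger amounts of compound. Compound 1 `CC(C)c1cc(NNC(=O)Nc2cc(Cl)nc(Cl)c2)nc2c1c(C(F)(F)F)nn2C` gives 27200 nM, compound 2 `CCCc1cc(NNC(=O)Nc2cc(Cl)nc(Cl)c2)nc2c1cnn2C` gives 76200 nM, and compound 3 `Cc1nn(C)c2nc(NNC(=O)Nc3cc(Cl)nc(Cl)c3)cc(-c3ccc(F)cc3)c12` gives 25200 nM. Compound 3 holds the lowest of the three numbers; its gap to compound 1 lies within the usual scatter, while the gap to compound 2 lies beyond it. Compound 4 `COc1ccc(-c2cc(NNC(=O)Nc3cc(Cl)nc(Cl)c3)nc3c2c(C)nn3C)cc1` has not yet been measured. It differs from compound 3 in one place: methoxy in place of fluoro on an aromatic carbon. Among the measured compounds shown here, no measured pair shows this change, so no step can be borrowed. A step of a 1.0-fold lower number from compound 3 to compound 4 (0.00 log units; within the scatter) is expected, small and not reaching beyond the scatter. For compound 4 in this assay the estimate is 25000 nM, ranging from 10000 nM to 60000 nM.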

Compound 4, half-maximal effective concentration: 82300 nM
Estimate against measurement, compound 4: 3.3-fold (0.52 log units) below; measured number outside the range, above it.
By their numbers in this assay, from the lowest: compounds 3 and 1 (each within the scatter of the next); then compounds 2 and 4 (each within the scatter of the next).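

In this assay the change from 4-fluorophenyl to 4-methoxyphenyl gives a 3.3-fold higher number from compound 3 to compound 4 (0.51 log units; beyond the scatter) and so shows that the group at this position on the aromatic ring can shift the number beyond the scatter. This is the first pair shown that differs in only one place, which makes it the first direct reading of a single change here. Nothing available explains this step.

Going by these compounds, whether an amine or a methyl group at this position would give a number closer to that of fluoro or methoxy remains open. So does whether the same swap would give a similar step on another set of substituents around the core.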